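A few compounds are considered here, and "the series" means these few. Any claim that something is new, unique, unknown or untested is made for them only; others in the source may bear on it.

Measured so far:
Compound 1, `CC(=O)Nc1cc(Nc2cc(NC3CC3)n3ncc(C#N)c3n2)ccc1N1CC[C@H](N(C)C)C1`: in an ADME assay on cells (Hepatocyte, Rattus norvegicus) for metabolic stability (on this read-out lower numbers stand for slow clearance and higher numbers for fast clearance), compound 1 gives 2.5 uL/min.
Compound 2, `CCN(CCN)c1ccc(Nc2cc(NC3CC3)n3ncc(C#N)c3n2)cc1NC(C)=O`: in this assay compound 2 gives 2 uL/min.

Of the two numbers shown, compound 1 stands at the top, but the only recorded step, a 1.3-fold lower number from compound 1 to compound 2 (0.10 log units; within the scatter), is within the scatter, so the two compounds cannot be told apart on this read-out. That step swapped one group for another on an aromatic carbon of the shared core.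

Compound 3, `CC(=O)Nc1cccc(Nc2cc(NC3CC3)n3ncc(C#N)c3n2)c1`, has not yet been measured. Its change from compound 1 is hydrogen in place of 3-(dimethylamino)pyrrolidin-1-yl on an aromatic carbon. Among the compounds with values here, no measured step strips a group from that place entirely; the one step in hand, from compound 1 to compound 2, exchanged the group for a different one and left the number within the scatter. With only that to lean on, compound 3 is expected to show no step beyond the scatter, since compound 1 gives 2.5 uL/min and compound 2 gives 2 uL/min. Compound 3 is therefore estimated at 2.5 uL/min, with a range from 1.2 uL/min to 5.5 uL/min. The step this estimate means is no change at the digits printed from compound 1 to compound 3 (within the scatter), expected to stay within the scatter.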

Compound 3, intrinsic clearance in a liver preparation (reported as CLH), per the amount of preparation that the assay uses: 26 uL/min
Compound 3: middle estimate off by 10-fold (1.02 log units), on the low side; measured number above the stated range.
By their numbers in this assay, from the lowest: compounds 2 and 1 (each within the scatter of the next); then compound 3.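

In this assay, this position on the aromatic ring, ortho to an acetamido group, turns out to matter a great deal. Replacing 3-(dimethylamino)pyrrolidin-1-yl with hydrogen gives a large step (a 10-fold higher number from compound 1 to compound 3 (1.02 log units; beyond the scatter)), and replacing the open chain of compound 2 with hydrogen gives one of similar scale (a 13-fold higher number from compound 2 to compound 3 (1.11 log units; beyond the scatter)). The earlier exchange of the ring-bearing group for the chain left the number within the scatter, so it could have suggested that this position had little influence, whereas these steps show that having a group there, either of the two tested, goes with a much lower number than having hydrogen there, and nothing available explains this gap.

The compounds shown leave open how much of a group is needed at this position, since a single methyl or methoxy group could sit near compound 3 or near compounds 1 and 2. They also leave open whether the nitrogen atoms shared by both groups matter, which an all-carbon butyl chain or a morpholine ring, with oxygen in place of one nitrogen, could help to test.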